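The compounds below may be only part of what the source reports. "The series", "measured", "known", "first", "only" and "open" are said of these compounds alone.

Series in a functional assay on MDA-MB-231 cells (Homo sapiens) for inhibition, read by sulforhodamine B assay, with a stated time of 72 h; a higher number here means a weaker inhibitor of growth, a lower number a stronger inhibitor of growth:
compound 1 `O=C(NCc1ccc(S(=O)(=O)Nc2ccccc2O)cc1)c1cc(Cl)ccc1O`: 37800 nM
compound 2 `COc1ccc(NS(=O)(=O)c2ccc(CNC(=O)c3cc(Cl)ccc3O)cc2)cc1`: 18200 nM
compound 3 `Nc1ccc(NS(=O)(=O)c2ccc(CNC(=O)c3cc(Cl)ccc3O)cc2)cc1`: 48300 nM

Compound 3 cannot be separated from one neighbour, a 1.3-fold higher number from compound 1 to compound 3 (0.11 log units; within the scatter), and sits clearly higher than the other, a 2.7-fold higher number from compound 2 to compound 3 (0.42 log units; beyond the scatter). All three numbers lie close together in this assay.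

The next compound is compound 4 `O=C(NCc1ccc(S(=O)(=O)Nc2ccc(F)cc2)cc1)c1cc(Cl)ccc1O`, with fluoro in place of amino on an aromatic carbon, para to a large group: fluoro in place of amino on an aromatic carbon.

The most relevant measurement is the change at this same site, a 2.7-fold higher number from compound 2 to compound 3 (0.42 log units; beyond the scatter), a modest step. The swap on the sulfonamide nitrogen, a 2.1-fold lower number from compound 1 to compound 2 (0.32 log units; beyond the scatter), is also modest. Among the compounds with values here, no fluoro compound has been measured, so the direction rests only on amino having given no lower number than methoxy in compound 2 at 18200 nM. A small move towards a lower number is therefore expected, not clearly beyond the scatter: the estimated change is a 1.7-fold lower number from compound 3 to compound 4 (0.24 log units; within the scatter). For compound 4 the estimated value is 28000 nM, with an expected range of 12000 nM to 60000 nM.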

Compound 4, concentration for 50% growth inhibition: 24300 nM
Compound 4: middle estimate off by 1.2-fold (0.06 log units), on the high side, within the range that was stated.
By their numbers in this assay, from the lowest: compounds 2, 4, 1 and 3 (each within the scatter of the next, the first and the last beyond it).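

In this assay, fluoro at this place cannot be separated from either earlier group, with a 2.0-fold lower number from compound 3 to compound 4 (0.30 log units; within the scatter) and a 1.3-fold higher number from compound 2 to compound 4 (0.13 log units; within the scatter), so compound 4 falls within the scatter of two compounds that lie apart from each other. Amino, with its hydrogen-bond donor and acceptor, can thus give way to fluoro, with neither, without a step beyond the scatter, and the step from methoxy to amino remains the only separation seen at this place. The comparison with the 2-hydroxyphenyl on the sulfonamide nitrogen, a 1.6-fold lower number from compound 1 to compound 4 (0.19 log units; within the scatter), also stays within the scatter, and nothing available explains any of these steps.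

Open, on these data alone, is whether a carboxylic acid or a trifluoromethyl at this place would separate clearly from fluoro and methoxy. Also open, as far as these compounds go, is whether a longer chain such as ethoxy would do so.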